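The compounds below may be only part of what the source reports. "The series", "measured", "known", "first", "only" and "open" are said of these compounds alone.

For the measured compounds named here, compound 2 `Cc1cccc2ccn(CCCCN3CCN(C(c4ccccc4)c4ccccc4)CC3)c12` holds the higher of the two numbers so far in an assay on RPMI-8226 cells for antagonist activity at P2X purinoceptor 7 (Homo sapiens), read by calcium flux; on this read-out higher numbers stand for weaker inhibition and lower numbers for stronger inhibition: compound 2 gives 2300 nM. Compound 1 `O=c1[nH]c2ccccc2n1CCCCCN1CCN(C(c2ccccc2)c2ccccc2)CC1` gives 560 nM in this assay. Compound 3 `COC(=O)c1cccc2ccn(CCCCN3CCN(C(c4ccccc4)c4ccccc4)CC3)c12` gives only a limit in this assay, > 10000 nM, and sits at the limit of > 10000 nM in this assay, at which 1 of the 3 values shown sits.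

Two measured steps exist. Going by the values given here, the step of a 4.1-fold higher number from compound 1 to compound 2 (0.61 log units; beyond the scatter) is the one that exchanges one bicyclic heteroaromatic group for another at the chain end, and it is the step most like the one under study. The step of an at least 4.3-fold higher number from compound 2 to compound 3 (0.63 log units; beyond the scatter) alters a substituent on the ring that is now to be removed, so it bears only indirectly.

Compound 4 `c1ccc(-c2nnnn2CCCCN2CCN(C(c3ccccc3)c3ccccc3)CC2)cc1` is not yet measured. It differs from compound 2 by 5-phenyl-1H-tetrazol-1-yl in place of 7-methyl-1H-indol-1-yl on a saturated chain carbon, four bonds along the chain from an amine nitrogen in a ring. Since the comparable exchange a 4.1-fold higher number from compound 1 to compound 2 (0.61 log units; beyond the scatter) moved the number beyond the scatter, a step of modest size is expected here too, in either direction, with no strong reason to favour one side. Compound 4 is therefore expected to give about 1500 nM in this assay, within a range of 400 nM to 6000 nM, which corresponds to an expected step of a 1.5-fold lower number from compound 2 to compound 4 (0.19 log units; within the scatter).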

Compound 4, half-maximal inhibitory concentration: 3200 nM
The estimate for compound 4 lay 2.1-fold (0.33 log units) below the measured number; measured number inside the range.
By their numbers in this assay, from the lowest: compound 1; then compounds 2 and 4 (each within the scatter of the next). At a limit, above all of these: compound 3.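

Replacing 7-methyl-1H-indol-1-yl with 5-phenyl-1H-tetrazol-1-yl at this chain position gives no resolvable change in this assay (a 1.4-fold higher number from compound 2 to compound 4 (0.14 log units; within the scatter)), although the entering group has 4 hydrogen-bond acceptors and the leaving group 1. Compound 4 also stays apart from compound 1 (a 5.7-fold higher number from compound 1 to compound 4 (0.76 log units; beyond the scatter)), so on the measured chain-end exchanges, compound 1 holds the lowest number, while compounds 2 and 4 cannot be separated from each other. No measurement shown accounts for either step.

From the compounds shown here alone, it remains open whether the gap to compound 1 can be closed from the 5-phenyl-1H-tetrazol-1-yl series. An amine or a carboxylic acid on its phenyl ring would test whether this group responds to substitution as the 7-methyl-1H-indol-1-yl group did in compound 3.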